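Nitro for Trifluoromethyl: Expected Effect on Vero Cytotoxicity

The source may report more compounds than this note shows. Statements on the series, on what has been measured and on what is new or still open speak of the compounds shown alone.

Of the compounds shown here, three have so far been measured in an ADME assay on Vero cells (Chlorocebus sabaeus) for cytotoxicity; a higher number here means a weaker inhibitor, a lower number a stronger inhibitor. Within the data shown here, compound 1 `COc1ccc(Cn2cc(CNC(=O)c3ccc([N+](=O)[O-])o3)nn2)cc1F` gives 312000 nM, and compound 2 `COc1ccc(Cn2cc(CNC(=O)c3ccc([N+](=O)[O-])o3)nn2)cc1O` gives 174000 nM; the one single-point step between them, a 1.8-fold lower number from compound 1 to compound 2 (0.25 log units; within the scatter), is hydroxy in place of fluoro on an aromatic carbon. Compound 3 `O=C(NCc1cn(Cc2ccc(C(F)(F)F)cc2)nn1)c1ccc([N+](=O)[O-])o1` gives 289000 nM, a number that sits within the scatter of compound 1 and of compound 2 alike. Compound 4 `O=C(NCc1cn(Cc2ccc([N+](=O)[O-])cc2)nn1)c1ccc([N+](=O)[O-])o1` differs from compound 3 by nitro in place of trifluoromethyl on an aromatic carbon. Among the measured compounds shown here, no measured step bears directly on this change; the only step available, the fluoro-to-hydroxy swap, stayed within the scatter, so no shift beyond the scatter is expected in this assay. Compound 4 is therefore estimated at 280000 nM, between 140000 nM and 560000 nM. The expected step is a 1.0-fold lower number from compound 3 to compound 4 (0.01 log units; within the scatter), essentially none.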

Compound 4, half-maximal inhibitory concentration: 291000 nM
Compound 4: middle estimate off by 1.0-fold (0.02 log units), on the low side; the range from low to high includes it.
By their numbers in this assay, from the lowest: compounds 2, 3, 4 and 1 (each within the scatter of the next).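

In this assay, among these compounds, the aromatic carbon para to a large group takes nitro in place of trifluoromethyl with no visible shift, a 1.0-fold higher number from compound 3 to compound 4 (0.00 log units; within the scatter), the first direct reading of this change. The whole benzyl substituent shows the same flatness, since 4-nitrophenyl gives a 1.7-fold higher number from compound 2 to compound 4 (0.22 log units; within the scatter) and a 1.1-fold lower number from compound 1 to compound 4 (0.03 log units; within the scatter), both steps staying within the scatter. Nothing available explains why these compounds read alike. Going by these compounds, whether an amine or a carboxylic acid on this aromatic carbon would also stay within the scatter remains open, as does any replacement of the nitro on the shared core.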